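The source may hold more compounds than are shown below. What is called first, only, known or untested is meant among the compounds shown, and "the series" means these compounds.

Measured compounds:
- compound 1, `CCCCNC(=O)c1c(N)sc(-c2ccc(Cl)cc2)c1-c1ccc(Cl)cc1`, gives 17800 nM in a functional assay on PC-3 cells (Homo sapiens) for inhibition, read by sulforhodamine B assay, with a stated time of 72 h; on this read-out lower numbers stand for stronger inhibition and higher numbers for weaker inhibition
- compound 2, `CC(=O)Nc1sc(-c2ccc(Cl)cc2)c(-c2ccc(Cl)cc2)c1C(=O)N1CCCCC1`, gives 10300 nM in this assay
- compound 3, `CS(=O)(=O)Nc1sc(-c2ccc(Cl)cc2)c(-c2ccc(Cl)cc2)c1C(=O)NC1CC1`, gives "not determined" (no result reported) in this assay

Among the two compounds with a number in this assay, compound 1 has the higher one, and compound 2 sits a little lower. That gap lies within the usual scatter of repeated runs, so the two values show no real difference in how strongly the compounds inhibit the cells. Compound 3 belongs to the same series but gives no number at all, so it adds nothing to the comparison.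

Compound 4, `COC(=O)c1c(N)sc(-c2ccc(Cl)cc2)c1-c1ccc(Cl)cc1`, has not yet been measured. It is derived from compound 1 by a single change: methoxy in place of butylamino on a carbonyl carbon. The rest of the shared core, with its two chlorophenyl groups and its amino group, is untouched.

Going by the values given here, no pair of measured compounds differing in one place is available, so there is no measured step to lean on. The expectation is therefore cautious: compound 4 is estimated at about 20000 nM, with a plausible range from 7000 nM to 60000 nM, which means an expected step of a 1.1-fold higher number from compound 1 to compound 4 (0.05 log units; within the scatter) of no more than the scatter.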

Compound 4, half-maximal inhibitory concentration: 2780 nM
Beside the measured number, compound 4's estimate is 7.2-fold (0.86 log units) above it, and the stated range ends above it.
By their numbers in this assay, from the lowest: compound 4; then compounds 2 and 1 (each within the scatter of the next).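

In this assay, going by these compounds alone, putting methoxy in place of butylamino on a carbonyl carbon gives a 6.4-fold lower number from compound 1 to compound 4 (0.81 log units; beyond the scatter), the first change that can be read on its own, since the earlier compounds differ from each other in more than one place. It shows that the group on this carbonyl carbon can move the number beyond the scatter while the two chlorophenyl groups, the amino group and the rest of the shared core stay untouched. The swap changes several things at once, as five heavy atoms and a hydrogen-bond donor leave while two heavy atoms and a hydrogen-bond acceptor enter, and no measurement shown here ties the lower number to any one of these differences.

Butoxy on the same carbonyl carbon would keep the length of the chain while exchanging the amide nitrogen for oxygen, and methylamino would keep the nitrogen while shortening the chain, so this pair would begin to separate the two differences. On these data alone, how a carboxylic acid at this place, or a longer alkoxy chain, would read also remains open.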